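Removing a fluorine from a benzothiazole urea

A few compounds are considered here, and "the series" means these few. Any claim that something is new, unique, unknown or untested is made for them only; others in the source may bear on it.

Measured compounds:
compound 1 `O=C(Nc1ccc2sc(-c3ccccc3)nc2c1)c1ccccc1`: 0.833 h
compound 2 `O=C(Nc1ccc2sc(-c3cccc(F)c3)nc2c1)N1CCCC1`: 0.2 h

In an ADME assay on microsomes from liver (Mus musculus) for metabolic stability, read by mass spectrometry, using NADPH, tested at 1.5 uM (on this read-out lower numbers stand for a shorter-lived compound and higher numbers for a longer-lived compound), compound 1 gives 0.833 h, and compound 2 gives 0.2 h, the lower of the two values, with the gap between them beyond the scatter. Compound 3 `O=C(Nc1ccc2sc(-c3ccccc3)nc2c1)N1CCCC1` has not been measured. It differs from compound 2 in one place: hydrogen in place of fluoro on an aromatic carbon. Among the compounds with values here, no measured pair shows this same change, so its effect here is unknown. The step is expected to be small, no change at the digits printed from compound 2 to compound 3 (within the scatter), with no direction beyond the scatter. Compound 3 is therefore estimated at 0.2 h, within 0.08 h to 0.5 h.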

Compound 3, half-life: 0.3 h
Compound 3: middle estimate off by 1.5-fold (0.18 log units), on the low side, within the range that was stated.
By their numbers in this assay, from the lowest: compounds 2 and 3 (each within the scatter of the next); then compound 1.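

In this assay the change from 3-fluorophenyl to phenyl gives a 1.5-fold higher number from compound 2 to compound 3 (0.18 log units; within the scatter), so the fluoro at this place makes no readable difference to the half-life. Within the data shown here, putting pyrrolidin-1-yl in place of phenyl on the carbonyl carbon gives a 2.8-fold lower number from compound 1 to compound 3 (0.44 log units; beyond the scatter), the only one of these two steps beyond the scatter. Nothing available accounts for either step.

Still open, as far as these compounds go, is whether a chlorine or a methoxy group at the same place would behave like the fluoro, and whether a piperidine or a morpholine on the carbonyl carbon would sit nearer compound 3 or compound 1.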